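The compounds below may be only part of what the source reports. "The series", "measured", "known", "first", "only" and "open" are said of these compounds alone.

In an ADME assay on microsomes from liver (Homo sapiens) for metabolic stability, read by LC-MS, using NADPH, with stated times of 5 min and 30 min, tested at 1 uM (on this read-out higher numbers stand for fast clearance and lower numbers for slow clearance), compound 1 (`Cn1nccc1-c1cnc(NCc2c(F)ccc3c2CCO3)c2cn[nH]c(=O)c12`) gives 14 mL.min-1.g-1 and compound 2 (`Cc1ncccc1-c1cnc(NCc2c(F)ccc3c2CCO3)c2ncc(=O)[nH]c12`) gives 21 mL.min-1.g-1, two values within the usual scatter of each other. Compound 3 (`CC(=O)N1CCC(c2cnc(NCc3c(F)ccc4c3CCO4)c3cn[nH]c(=O)c23)CC1`) keeps the core of compound 1 but carries 1-acetylpiperidin-4-yl in place of 1-methyl-1H-pyrazol-5-yl on an aromatic carbon. Going by the values given here, no measured pair shows this swap on its own, so any forecast is uncertain. A modest rise in this assay is expected, an estimated step of a 1.6-fold higher number from compound 1 to compound 3 (0.20 log units; within the scatter). For compound 3 the estimated value is 22 mL.min-1.g-1, with an expected range from 10 mL.min-1.g-1 to 50 mL.min-1.g-1.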

Compound 3, intrinsic clearance in microsomes: 207 mL.min-1.g-1
Compound 3: the middle estimate sits 9.4-fold (0.97 log units) below what was measured, outside the stated range (above it).
By their numbers in this assay, from the lowest: compounds 1 and 2 (each within the scatter of the next); then compound 3.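

Swapping 1-methyl-1H-pyrazol-5-yl for 1-acetylpiperidin-4-yl on this aromatic carbon gives a 15-fold higher number from compound 1 to compound 3 (1.17 log units; beyond the scatter) in this assay, so the group at this place can strongly change the clearance read-out. Going by these compounds alone, no earlier pair differing in one place could show this. Nothing at hand gives a reason for the rise. Still open, from the compounds shown here alone, is whether it follows the loss of the aromatic ring or the acetyl group, which a free piperidin-4-yl amine or a phenyl ring at this place could help separate. Going by these compounds, whether the same swap acts alike on another core also stays open.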